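Swapping the aryl group on the sulfonamide nitrogen

The compounds below may be only part of what the source reports. "The series", "measured", "known", "first", "only" and "open" are said of these compounds alone.

Of the compounds shown here, three sharing one core have been measured in a functional assay on CHO cells for antagonist activity at prostaglandin E2 receptor EP1 subtype (Homo sapiens), read by FLIPR and calcium flux; a lower number here means a stronger inhibitor, a higher number a weaker inhibitor. Compound 1 `CCc1ccccc1N(Cc1nnc(Cc2ccccc2)o1)S(=O)(=O)c1ccc(C)cc1` gives 398 nM, compound 2 `CCc1ccccc1N(Cc1nnc(Cc2ccc(Cl)cc2)o1)S(=O)(=O)c1ccc(C)cc1` gives 316 nM, and compound 3 `CCOc1ccc(Cc2nnc(CN(c3ccccc3CC)S(=O)(=O)c3ccc(C)cc3)o2)cc1` gives 39.8 nM, the lowest of the three numbers. The step of a 1.3-fold lower number from compound 1 to compound 2 (0.10 log units; within the scatter) comes from chloro in place of hydrogen on an aromatic carbon, while the step of a 10-fold lower number from compound 1 to compound 3 (1.00 log units; beyond the scatter) and the step of a 7.9-fold lower number from compound 2 to compound 3 (0.90 log units; beyond the scatter) come from ethoxy in place of hydrogen or of chloro on an aromatic carbon.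

Compound 4 `CCOc1ccc(Cc2nnc(CN(c3cccc(Cl)c3Cl)S(=O)(=O)c3ccc(C)cc3)o2)cc1` differs from compound 3 elsewhere: 2,3-dichlorophenyl in place of 2-ethylphenyl on a sulfonamide nitrogen. For the measured compounds named here, none of the measured steps touches this part of the molecule, so there is no direct guide to the size or direction of the change in this assay. Compound 4 is therefore expected to stay close to compound 3, with the step of a 1.5-fold higher number from compound 3 to compound 4 (0.18 log units; within the scatter) most likely within the scatter, but with wide uncertainty in either direction. The estimate for compound 4 in this assay is 60 nM, in a range from 15 nM to 250 nM.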

Compound 4, inhibition constant: 31.6 nM
Estimate against measurement, compound 4: 1.9-fold (0.28 log units) above, and the stated range covers the measured number.
By their numbers in this assay, from the lowest: compounds 4 and 3 (each within the scatter of the next); then compounds 2 and 1 (each within the scatter of the next).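

In this assay, this is the only step shown on a sulfonamide nitrogen, and it reads a 1.3-fold lower number from compound 3 to compound 4 (0.10 log units; within the scatter). With the ethoxy group held fixed, 2,3-dichlorophenyl thus serves in place of 2-ethylphenyl without a difference that can be told apart, so this position accepts a change from an ethyl group to two chlorines on the same aromatic ring. Nothing measured here accounts for the two aryl groups reading alike.

The compounds shown leave open whether an aromatic ring is needed on the sulfonamide nitrogen at all, or whether a cyclohexyl or pyridyl group would read the same. They also leave open whether the same swap would read alike in compound 1 or compound 2, which carry no ethoxy group.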